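Notes on compound 4 against three measured analogues

A few compounds are considered here, and "the series" means these few. Any claim that something is new, unique, unknown or untested is made for them only; others in the source may bear on it.

Measured compounds:
compound 1 `O=C(/C(=C\c1ccc(Br)cc1)SCc1ccc(Cl)cc1)c1ccc(Br)cc1` — 1000 nM
compound 2 `COc1ccc(S/C(=C/c2ccc(Br)cc2)C(=O)c2ccc(Br)cc2)cc1` — 20000 nM
compound 3 `O=C(/C(=C\c1ccc(Br)cc1)SCc1ccc(F)cc1)c1ccc(Br)cc1` — 25000 nM

In a functional assay on DU-145 cells (Homo sapiens) for inhibition, read by trypan blue exclusion, with a stated time of 96 h (on this read-out higher numbers stand for weaker inhibition of growth and lower numbers for stronger inhibition of growth), compound 1 stands lowest of the three numbers, with a 20-fold higher number from compound 1 to compound 2 (1.30 log units; beyond the scatter) and a 25-fold higher number from compound 1 to compound 3 (1.40 log units; beyond the scatter) both beyond the scatter, while a 1.3-fold higher number from compound 2 to compound 3 (0.10 log units; within the scatter) stays within it.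

Compound 4 `CN(C)c1ccc(/C=C(/SCc2ccc(Cl)cc2)C(=O)c2ccc(Br)cc2)cc1` is not yet measured. It differs from compound 1 by dimethylamino in place of bromo on an aromatic carbon. Going by the values given here, no measured step exchanges this group or alters this ring, so none bears on the change directly; the two large steps away from compound 1 show only that single changes elsewhere in the shared core cost much, without giving a direction here. Compound 4 is therefore expected close to compound 1, with a wide range, amounting to a 2.0-fold higher number from compound 1 to compound 4 (0.30 log units; within the scatter). For compound 4 the estimate in this assay is 2000 nM, from 250 nM to 16000 nM.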

Compound 4, concentration for 50% growth inhibition: 10000 nM
Compound 4: middle estimate off by 5.0-fold (0.70 log units), on the low side; the range from low to high includes it.
By their numbers in this assay, from the lowest: compound 1; then compounds 4, 2 and 3 (each within the scatter of the next, the first and the last beyond it).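

In this assay, the bromo on an aromatic carbon, para to a large group, proves sensitive to change: dimethylamino in its place gives a 10-fold higher number from compound 1 to compound 4 (1.00 log units; beyond the scatter). Going by these compounds alone, this ring was untouched in the earlier steps, so the result adds a further site where a single change moves the number beyond the scatter, here by a modest step. Nothing available accounts for this step.

On these data alone, whether a chloro, a methoxy or a primary amine at this position would stay closer to compound 1 remains open. Also open, as far as these compounds go, is how dimethylamino behaves with 4-fluorobenzyl on the sulfur.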